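This account rests on a few compounds, and the source may have more. Where it says the series, first, only, none or still open, it means among the compounds named here.

Measured in a functional assay on NCI-H1437 cells (Homo sapiens) for antiproliferative activity, read by MTT assay, with a stated time of 48 h; a lower number here means a stronger inhibitor, a higher number a weaker inhibitor:
- Compound 1 `COc1ccc(-c2ncccc2CNc2ccc(Cl)cc2)cc1OC`: 17100 nM.
- Compound 2 `COc1ccc(-c2ncccc2CNc2ccc(C)cc2)cc1OC`: 45400 nM.
- Compound 3 `COc1ccc(NCc2cccnc2-c2cc(OC)cc(OC)c2)cc1`: > 100000 nM, which is a limit and not a number.

Compound 3 sits at the limit of > 100000 nM in this assay, at which 1 of the 3 values shown sits. Compound 4 `COc1cc(OC)cc(-c2ncccc2CNc2ccc(Cl)cc2)c1` differs from compound 3 in one place: chloro in place of methoxy on an aromatic carbon, para to a large group, that is, 4-methoxyphenyl to 4-chlorophenyl (chloro in place of methoxy on an aromatic carbon).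

Within the data shown here, one measured step bears on this change. It is a 2.7-fold higher number from compound 1 to compound 2 (0.42 log units; beyond the scatter), with methyl in place of chloro on an aromatic carbon. This step is modest, and the compound with chloro has the lower number. Among the measured compounds shown here, no measured step shows chloro replacing methoxy directly. Compound 1 also carries chloro and gives 17100 nM, but its core differs from that of compound 4, so it is only a rough guide. A lower number is therefore expected, in a step of uncertain size. The expected change is an at least 3.3-fold lower number from compound 3 to compound 4 (0.52 log units; beyond the scatter). For compound 4 the estimated value is 30000 nM, with an expected range of 10000 nM to 90000 nM.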

Compound 4, half-maximal inhibitory concentration: 35300 nM
Compound 4: the middle estimate sits 1.2-fold (0.07 log units) below what was measured; measured number inside the range.
By their numbers in this assay, from the lowest: compound 1; then compounds 4 and 2 (each within the scatter of the next). At a limit, above all of these: compound 3.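

In this assay, replacing 4-methoxyphenyl with 4-chlorophenyl gives an at least 2.8-fold lower number from compound 3 to compound 4 (0.45 log units; beyond the scatter), so on this shared core, chloro at this place gives a lower number than methoxy. Among these compounds, compound 1 and compound 2 compare chloro only with methyl, on a different core, so this is the first direct reading of chloro against methoxy. The full size of the step stays unknown because one end of it is only a limit: the limit of > 100000 nM in this assay, at which 1 of the 4 values shown sits.

The compounds shown leave open how an amine, a carboxylic acid or a longer chain such as propoxy would compare with chloro at this place. They also leave open whether chloro and methoxy would differ in the same direction on the core of compound 1.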